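Methyl next to the ring nitrogen: a pyridine substituent step

The source may hold more compounds than are shown below. What is called first, only, known or untested is meant among the compounds shown, and "the series" means these compounds.

Three compounds have been measured in an assay on CHO cells for binding affinity to corticotropin-releasing factor receptor 1 (Homo sapiens); on this read-out higher numbers stand for weaker inhibition and lower numbers for stronger inhibition:

compound 1 `CCCN(CCC)c1cc(C)nc2c(-c3ccc(N(C)C)nc3)c(C)nn12`, 4.2 nM
compound 2 `CCCC(CCC)Nc1cc(C)nc2c(-c3cnc(N(C)C)cc3C)c(C)nn12`, 4.8 nM
compound 3 `CCN(Cc1ccc(Cl)cc1)c1cc(C)nc2c(-c3cnc(N(C)C)cc3C)c(C)nn12`, 1.3 nM

Among these three numbers, compound 1 holds the second highest. Its nearest neighbour is compound 2, whose number lies within the usual scatter of compound 1, so no order between the two can be read from the data. The furthest is compound 3, whose number is lower than that of compound 1 by a margin beyond the scatter. Within the data shown here, compounds 2 and 3 differ from compound 1 at more than one place, so no single step between measured compounds is available.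

The next compound, compound 4 `CCCN(CCC)c1cc(C)nc2c(-c3ccc(N(C)C)nc3C)c(C)nn12`, differs from compound 1 at one place only: methyl in place of hydrogen on an aromatic carbon. Compounds 2 and 3 both carry a methyl on their pyridine ring, and both give low numbers in this assay, which suggests that a methyl on that ring is at least tolerated, though neither provides a clean comparison to compound 1. The step is therefore expected to be small, with at most a slight move toward a lower number. For compound 4 the estimated value in this assay is 3 nM, within a range of 1 nM to 9 nM, which means an expected step of a 1.4-fold lower number from compound 1 to compound 4 (0.15 log units; within the scatter) that lies within the scatter.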

Compound 4, inhibition constant: 2.2 nM
Compound 4: the middle estimate sits 1.4-fold (0.13 log units) above what was measured; measured number inside the range.
By their numbers in this assay, from the lowest: compounds 3, 4, 1 and 2 (each within the scatter of the next, the first and the last beyond it).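

Among these compounds, with compound 4, the methyl in place of hydrogen on an aromatic carbon can be read on its own for the first time in this assay: the step is a 1.9-fold lower number from compound 1 to compound 4 (0.28 log units; within the scatter), with the rest of the structure unchanged. The result shows that a methyl next to the ring nitrogen, ortho to a large group and meta to a dimethylamino group, is tolerated on this read-out, but no order between the two compounds can be drawn from it. No measurement shown here offers any explanation for this result.

The compounds shown leave open what an ethyl, a methoxy or an amine would give on this same aromatic carbon, and so how much room there is for anything beyond a methyl at this place. Going by these compounds, it also remains open whether a methyl on another carbon of this ring would give a similar result, and whether this step would hold with a different amine side chain on the shared core.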